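The source may report more compounds than this note shows. Statements on the series, on what has been measured and on what is new or still open speak of the compounds shown alone.

For the measured compounds named here, in a functional assay on NCI-H460 cells (Homo sapiens) for inhibition, read by MTT assay, with a stated time of 72 h (on this read-out lower numbers stand for stronger inhibition and higher numbers for weaker inhibition), compound 2 `CCN(CC)CCCn1c(=O)c(=Cc2ccc(F)cc2F)s/c1=C1\C(=O)Nc2cc(F)ccc21` gives 2330 nM, the only number among the two values shown. Compound 1 `CCN(CC)CCCn1c(=O)c(=Cc2ccccc2O)s/c1=C1\C(=O)Nc2ccccc21` reaches only a limit of the assay there, > 200000 nM, which is the limit of > 200000 nM in this assay, at which 1 of the 2 values shown sits. Compound 3 `CCN(CC)CCCn1c(=O)c(=Cc2ccc(F)cc2F)s/c1=C1\C(=O)Nc2ccccc21` differs from compound 2 by hydrogen in place of fluoro on an aromatic carbon. Going by the values given here, no measured pair shows this change on its own, so the step is untested. The step from compound 2 to compound 3 is expected to be small, leaning if anything toward weaker inhibition, a 1.5-fold higher number from compound 2 to compound 3 (0.18 log units; within the scatter). Compound 3 is therefore estimated at 3500 nM, between 1200 nM and 12000 nM.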

Compound 3, half-maximal inhibitory concentration: 5470 nM
Beside the measured number, compound 3's estimate is 1.6-fold (0.19 log units) below it; low and high end bracket the measured number.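

In this assay, the fluoro on this aromatic carbon of the fused system now has a step of its own: a 2.3-fold higher number from compound 2 to compound 3 (0.37 log units; beyond the scatter), so hydrogen there costs a modest amount of inhibition. The change on the double-bonded chain carbon weighs far more, as 2,4-difluorophenyl in place of 2-hydroxyphenyl gives an at least 36-fold lower number from compound 1 to compound 3 (1.56 log units; beyond the scatter). Compound 1 stands at a limit of the assay, not at a number: the limit of > 200000 nM in this assay, at which 1 of the 3 values shown sits.

The compounds shown leave open whether a chloro or methoxy group on this aromatic carbon would match fluoro. Also open, going by these compounds, is whether the large step comes from gaining the fluoro groups or from losing the hydroxy group.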